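This account rests on a few compounds, and the source may have more. Where it says the series, first, only, none or still open, it means among the compounds named here.

Measured so far:

- compound 1, `COc1ccc(C2=NN(C(=O)c3cccnc3Cl)C(c3ccc(Cl)cc3)C2)cc1`: in a functional assay on WM 266-4 cells (Homo sapiens) for antiproliferative activity, read by MTT assay, with a stated time of 24 h (a lower number here means a stronger inhibitor of growth, a higher number a weaker inhibitor of growth), compound 1 gives 780 nM.
- compound 2, `COc1ccc(C2=NN(C(=O)c3ccc(C)nc3)C(c3ccc(Cl)cc3)C2)cc1`: in this assay compound 2 gives 890 nM.
- compound 3, `O=C(c1cccnc1Cl)N1N=C(c2ccc(Cl)cc2)CC1c1ccc(Br)cc1`: in this assay compound 3 gives 7450 nM.

Compound 1 to compound 2 is one change, (6-methylpyridin-3-yl in place of 2-chloropyridin-3-yl on a carbonyl carbon), and it moves the number by a 1.1-fold higher number from compound 1 to compound 2 (0.06 log units; within the scatter), which is within the scatter. Compound 3 carries a different core from compound 1; the difference between the two cores is not broken down here, and compound 3 gives the highest number of the three, beyond the scatter from both.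

Compound 4, `Cc1ccc(C(=O)N2N=C(c3ccc(Cl)cc3)CC2c2ccc(Br)cc2)cn1`, is not yet measured. It differs from compound 3 by 6-methylpyridin-3-yl in place of 2-chloropyridin-3-yl on a carbonyl carbon, the same change as from compound 1 to compound 2, at the same place. Beside a 1.1-fold higher number from compound 1 to compound 2 (0.06 log units; within the scatter), a step of a 1.1-fold higher number from compound 3 to compound 4 (0.03 log units; within the scatter) is expected for compound 4, resting only on that one earlier pair. Compound 4 is therefore estimated at 8000 nM, expected between 4000 nM and 16000 nM.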

Compound 4, concentration for 50% growth inhibition: 7650 nM
Estimate against measurement, compound 4: 1.0-fold (0.02 log units) above, within the range that was stated.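

On the core of compound 3, 6-methylpyridin-3-yl in place of 2-chloropyridin-3-yl on a carbonyl carbon gives no change that can be told from scatter in this assay (a 1.0-fold higher number from compound 3 to compound 4 (0.01 log units; within the scatter)). The change thus carries from one core to the other with no detectable difference between the two steps: the same change on two cores in this assay, a 1.1-fold higher number (0.06 log units; within the scatter) from compound 1 to compound 2 and a 1.0-fold higher number (0.01 log units; within the scatter) from compound 3 to compound 4, 1.1-fold (0.05 log units) apart, within the scatter of two such steps. Going by these compounds alone, this rests on only two pairs in one assay, and it does not show that the change would stay silent on a third core or what underlies the flat result.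

Both groups shown on the carbonyl are substituted pyridin-3-yl rings. From the compounds shown here alone, how a piperidine amine, a carboxylic acid, or a longer chain in place of the methyl would behave at this place remains open.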